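Swapping the sulfonyl aryl group: what happens to clearance

A few compounds are considered here, and "the series" means these few. Any claim that something is new, unique, unknown or untested is made for them only; others in the source may bear on it.

This account follows one change among three related sulfones. Compound 1 `O=S(=O)(c1cccc(F)c1)c1cnc2c(F)cccc2c1-c1ccccc1F` and compound 2 `COc1ccc(S(=O)(=O)c2cnc3c(F)cccc3c2-c2cccc(OC)c2)cc1` were both tested in an ADME assay on microsomes from liver (Homo sapiens) for metabolic stability, tested at 2.5 uM; on this read-out higher numbers stand for fast clearance and lower numbers for slow clearance. In this assay compound 1 gives 0.21 mL/min, while compound 2 gives 2.87 mL/min, the highest of the two numbers; the gap between the two lies beyond the usual scatter, so compound 2 is cleared clearly faster than compound 1.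

Compound 3 `COc1cccc(-c2c(S(=O)(=O)c3cccc(F)c3)cnc3c(F)cccc23)c1` has not yet been measured. Compared with compound 2 it carries 3-fluorophenyl in place of 4-methoxyphenyl on a sulfonyl sulfur, the rest of the molecule being unchanged. The group that enters is the same one that compound 1 carries on its sulfonyl sulfur, and compound 1 gives the low value of 0.21 mL/min in this assay. On that basis the step is expected to go downward and to exceed the scatter: the estimated step of a 2.9-fold lower number from compound 2 to compound 3 (0.46 log units; beyond the scatter) in this assay reflects this expectation. Compound 3 is therefore estimated to give 1 mL/min in this assay, with a likely range from 0.35 mL/min to 2.9 mL/min.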

Compound 3, intrinsic clearance in a liver preparation (reported as CLH), per the amount of preparation that the assay uses: 2.6 mL/min
Estimate against measurement, compound 3: 2.6-fold (0.41 log units) below; measured number inside the range.
By their numbers in this assay, from the lowest: compound 1; then compounds 3 and 2 (each within the scatter of the next).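

In this assay the change on a sulfonyl sulfur, 3-fluorophenyl in place of 4-methoxyphenyl, gives a 1.1-fold lower number from compound 2 to compound 3 (0.04 log units; within the scatter) and so does not separate these two compounds, which share 3-methoxyphenyl on the aromatic carbon. The change at that aromatic carbon, 3-methoxyphenyl in place of 2-fluorophenyl with 3-fluorophenyl held on the sulfonyl sulfur, gives a 12-fold higher number from compound 1 to compound 3 (1.09 log units; beyond the scatter) and is the large step in this set, so the gap seen earlier between compound 1 and compound 2, which differ in two places, now has a single-place counterpart at the aromatic carbon rather than on the sulfonyl sulfur. Nothing at hand accounts for either step.

The three compounds leave open whether the sulfonyl change would stay as small with 2-fluorophenyl on the aromatic carbon, since it is seen here only with 3-methoxyphenyl there. Among these compounds, they also leave open how clearance would respond to quite different groups on the sulfonyl sulfur, such as a pyridine ring, an amine or a carboxylic acid, as only two substituted phenyl groups appear at that place.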